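From Chloro to Methyl in a Three-Compound Series

The source may hold more compounds than are shown below. What is called first, only, known or untested is meant among the compounds shown, and "the series" means these compounds.

Compound 1 `CC(C)=CCOc1ccc2c(c1)OC(c1ccccc1)CC2=O` gives 6070 nM
Compound 2 `CC(C)=CCOc1ccc2c(c1)OC(c1ccccc1Cl)CC2=O` gives 8020 nM
Compound 3 `CC(C)=CCOc1ccc2c(c1)OC(c1ccc(Cl)cc1)CC2=O` gives 6970 nM

In a functional assay (on this read-out lower numbers stand for stronger inhibition and higher numbers for weaker inhibition), compound 3 gives 6970 nM and cannot be separated from the other two compounds. The steps that reach it are a 1.1-fold higher number from compound 1 to compound 3 (0.06 log units; within the scatter) and a 1.2-fold lower number from compound 2 to compound 3 (0.06 log units; within the scatter), and neither lies beyond the scatter.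

Compound 4 `CC(C)=CCOc1ccc2c(c1)OC(c1ccc(C)cc1)CC2=O` differs from compound 3 in one place (methyl in place of chloro on an aromatic carbon), with methyl in place of chloro on an aromatic carbon, para to a large group. In other words, 4-chlorophenyl becomes 4-methylphenyl.

Going by the values given here, no measured step makes this exchange, and no measured compound carries methyl at this carbon. The nearest evidence is chloro in place of hydrogen on an aromatic carbon, which gave a 1.3-fold higher number from compound 1 to compound 2 (0.12 log units; within the scatter) in one case and a 1.1-fold higher number from compound 1 to compound 3 (0.06 log units; within the scatter) in the other. All three measured compounds stay within the scatter of one another, but this is thin support for a compound none of them resembles exactly. On that basis, no step beyond the scatter is expected in this assay, and no direction is favoured. The expected step is a 1.1-fold lower number from compound 3 to compound 4 (0.03 log units; within the scatter) and the estimate remains uncertain.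

In this assay the estimate for compound 4 is 6500 nM, expected to lie between 3500 nM and 12000 nM.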

Compound 4, half-maximal inhibitory concentration: 4440 nM
For compound 4 the middle estimate is 1.5-fold (0.17 log units) above the measured one; low and high end bracket the measured number.
By their numbers in this assay, from the lowest: compounds 4, 1, 3 and 2 (each within the scatter of the next).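

With methyl on this aromatic carbon, para to a large group, this assay gives a 1.4-fold lower number from compound 1 to compound 4 (0.14 log units; within the scatter) when methyl replaces hydrogen and a 1.6-fold lower number from compound 3 to compound 4 (0.20 log units; within the scatter) when methyl replaces chloro, and both steps lie within the scatter. Going by these compounds alone, the carbon has now carried hydrogen, chloro and methyl without a step beyond the scatter, although the set holds only one compound with each of these two groups there. The step that exchanges 2-chlorophenyl for 4-methylphenyl, a 1.8-fold lower number from compound 2 to compound 4 (0.26 log units; within the scatter) in size, is the largest among the four compounds and also stays within the scatter, and nothing available accounts for any of these small differences.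

The compounds shown leave open whether an amine, a methoxy group, a carboxylic acid or a longer chain such as butyl on this aromatic carbon would give a step beyond the scatter in this assay or would stay as close to the others as chloro and methyl do. They also leave open whether methyl on the carbon that carries chloro in the 2-chlorophenyl of compound 2 would read like compound 4.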